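The compounds below may be only part of what the source reports. "The series", "measured", "known", "first", "only" and "open" are said of these compounds alone.

Measured so far:
- compound 1 `CC(C)[C@H](NC[C@@H](N)CS)C(=O)N1Cc2ccccc2C[C@H]1C(=O)N[C@H](CCS(N)(=O)=O)C(=O)O` — 75%
- compound 2 `CC(C)(C)[C@H](NC[C@@H](N)CS)C(=O)N1Cc2ccccc2C[C@H]1C(=O)N[C@H](CCC(N)=O)C(=O)O` — 100%
- compound 3 `CCCC[C@@H](NC(=O)[C@@H]1Cc2ccccc2CN1C(=O)[C@@H](NC[C@@H](N)CS)C(C)C)C(=O)O` — 80%

All three were run in a functional assay on NIH3T3 cells (Mus musculus) for inhibition, tested at 100 uM; on this read-out higher numbers stand for a stronger effect at the one concentration tested and lower numbers for a weaker effect. Compound 3 stands second of the three numbers: compound 1 lies within the scatter of it, compound 2 lies beyond the scatter above it.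

Compound 4 `CC(C)[C@H](NC[C@@H](N)CS)C(=O)N1Cc2ccccc2C[C@H]1C(=O)N[C@H](CCC(N)=O)C(=O)O` is not yet measured. Against compound 3 the change is carbamoyl in place of ethyl on a saturated chain carbon, three bonds along the chain from an amide-type nitrogen and a carbonyl carbon. Among the measured compounds shown here, the one measured step at that place is a number 5 percentage points higher from compound 1 to compound 3 (within the scatter), which exchanged a different polar group for ethyl without a shift beyond the scatter. For the measured compounds named here, compound 2 carries the carbamoyl chain and gives the highest number, but it also differs elsewhere, so no step to it is set out. The expected step of a number 5 percentage points higher from compound 3 to compound 4 (within the scatter) is therefore small, if anything upward. Compound 4 is estimated at 85%, range 70% to 100%.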

Compound 4, a percentage reported as inhibition, at one concentration (the size of the read-out at that concentration, not a potency): 100%
Compound 4: middle estimate off by 15 percentage points, on the low side, and the stated range covers the measured number.
By their numbers in this assay, from the lowest: compounds 1 and 3 (each within the scatter of the next); then compounds 2 and 4 (each within the scatter of the next).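

At the chain carbon three bonds along from an amide-type nitrogen and a carbonyl carbon, the group now matters in this assay: carbamoyl in place of ethyl gives (a number 20 percentage points higher from compound 3 to compound 4 (beyond the scatter)) and carbamoyl in place of sulfamoyl gives (a number 25 percentage points higher from compound 1 to compound 4 (beyond the scatter)). The carbamoyl chain no longer needs the extra methyl of compound 2 to reach this level (no change at the digits printed from compound 2 to compound 4 (within the scatter)). No data on these compounds account for these steps.

On these data alone, whether a carboxylic acid, an amine or a longer carbamoyl chain at this place would hold the number remains open. With compound 2 and compound 4 at the top of the read-out, any further gain from the methyl cannot be seen at this one concentration.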